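A few compounds are considered here, and "the series" means these few. Any claim that something is new, unique, unknown or untested is made for them only; others in the source may bear on it.

Measured so far:
- compound 1 `CCOC(=O)C(=O)Nc1cccccc1=O`: 80%
- compound 2 `CCOC(=O)C(=O)Nc1ccccc(C)c1=O`: 40%

Both compounds were tested in a functional assay on the whole organism (strain Sprague-Dawley CD) for inhibition, with Rattus norvegicus as the target, read by paw edema, at a dose of 10 mg/kg by the intraperitoneal route; on this read-out higher numbers stand for a stronger effect at the one dose given and lower numbers for a weaker effect. Compound 1 gives 80% and compound 2 gives 40% in this assay. Going by the values given here, compound 2 therefore stands at the lower of the two numbers, and the only step seen so far, a number 40 percentage points lower from compound 1 to compound 2 (beyond the scatter), lies beyond the scatter and runs downward.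

The next compound, compound 3 `CCOC(=O)C(=O)Nc1ccccc(O)c1=O`, is not yet measured. Compared with compound 2 the difference is hydroxy in place of methyl on an aromatic carbon. Among the compounds with values here, no measured step shows a hydroxy group entering, so the only guide is the step from compound 1 to compound 2, in which a methyl group entered and the read-out fell sharply. Whether removing that methyl group and putting a hydroxy group in its place brings the number back toward compound 1, leaves it where compound 2 stands, or moves it elsewhere cannot be told from two compounds. The expected step of a number 10 percentage points higher from compound 2 to compound 3 (within the scatter) is therefore set near the middle of the two measured numbers, with a wide range. For compound 3 the estimate in this assay is 50%, expected to fall between 20% and 80%.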

Compound 3, a percentage reported as inhibition, in the whole organism at one dose (the size of the read-out at that dose, not a potency): 5%
Compound 3: the middle estimate sits 45 percentage points above what was measured; the measured number lies below the stated range.
By their numbers in this assay, from the lowest: compound 3; then compound 2; then compound 1.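

Hydroxy in place of methyl on this aromatic carbon, two ring bonds from the ring atom that bears a group of 8 heavy atoms, gives in this assay a number 35 percentage points lower from compound 2 to compound 3 (beyond the scatter), so swapping the methyl group for hydroxy does not bring the number back towards that of the unsubstituted compound. Hydroxy in place of hydrogen gives a number 75 percentage points lower from compound 1 to compound 3 (beyond the scatter), which means that both groups seen at this place lower the number, and among these three compounds hydrogen stands highest, then methyl, then hydroxy. Methyl and hydroxy each have 1 heavy atom, yet their numbers stand apart beyond the scatter, so the count of heavy atoms alone does not set the result here, and nothing shown explains the difference.

The compounds shown leave open whether any group at this place can match hydrogen, for instance a fluorine atom, a methoxy group or an amine. They also leave open whether methyl or hydroxy would lower the number as much on another carbon of the ring, or at a dose other than the single one given.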